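The source may report more compounds than this note shows. Statements on the series, on what has been measured and on what is new or still open speak of the compounds shown alone.

Going by the values given here, compound 2 `COc1ccc(CNCCCNS(=O)(=O)c2cc(C(F)(F)F)cc(C(F)(F)F)c2)cc1OC` is one of two compounds measured in a functional assay on BXPC-3 cells (Homo sapiens) for inhibition, read by MTT assay, with a stated time of 72 h; a lower number here means a stronger inhibitor of growth, a higher number a weaker inhibitor of growth; in this assay compound 2 gives 13000 nM. Compound 1 `O=S(=O)(NCCNCc1cccc2ccccc12)c1cc(C(F)(F)F)cc(C(F)(F)F)c1` gives 23000 nM in this assay, and the two numbers lie within the usual scatter of each other, so neither stands apart. Compound 3 `O=S(=O)(NCCCNCc1cccc2ccccc12)c1cc(C(F)(F)F)cc(C(F)(F)F)c1` is not yet measured; it differs from compound 2 in one place: naphthalen-1-yl in place of 3,4-dimethoxyphenyl on a saturated chain carbon bound to an amine nitrogen. Among the compounds with values here, no measured pair shows this change alone, so the expected step is small, in either direction or none beyond the scatter. The estimate for compound 3 in this assay is 18000 nM, expected to fall between 6000 nM and 50000 nM. The expected step is a 1.4-fold higher number from compound 2 to compound 3 (0.14 log units; within the scatter).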

Compound 3, concentration for 50% growth inhibition: 2700 nM
For compound 3 the middle estimate is 6.7-fold (0.82 log units) above the measured one, outside the stated range (below it).
By their numbers in this assay, from the lowest: compound 3; then compounds 2 and 1 (each within the scatter of the next).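

In this assay there is a 4.8-fold lower number from compound 2 to compound 3 (0.68 log units; beyond the scatter) when naphthalen-1-yl takes the place of 3,4-dimethoxyphenyl on a saturated chain carbon bound to an amine nitrogen. Going by these compounds alone, this shows that the group at this place can alter the number on its own, which the earlier compounds, differing in more than one place, could not show. No measurement here accounts for the change.

The swap adds a second aromatic ring and removes both methoxy groups at once, and the compounds shown cannot separate these two changes. A plain phenyl or a naphthalen-2-yl at this place remains an open question.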